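One More Methoxy on Compound 3

The source may report more compounds than this note shows. Statements on the series, on what has been measured and on what is new or still open speak of the compounds shown alone.

- compound 1 `Cc1ccc2[nH]c(-c3ccc(-c4ccc(-c5ccc(N(C)C)cc5)cc4)cc3)nc2c1` gives 7110 nM
- compound 2 `Cc1ccc2[nH]c(-c3ccc(-c4ccc(-c5cccc(Cl)c5)cc4)cc3)nc2c1` gives 3600 nM
- compound 3 `COc1ccc(-c2ccc(-c3ccc(-c4nc5cc(C)ccc5[nH]4)cc3)cc2)cc1OC` gives 3510 nM

In a functional assay on SiHa cells (Homo sapiens) for inhibition, read by sulforhodamine B assay (a higher number here means a weaker inhibitor of growth, a lower number a stronger inhibitor of growth), compound 3 gives 3510 nM and stands level with compound 2, while compound 1 has the higher number. The next structure, compound 4 `COc1cc(-c2ccc(-c3ccc(-c4nc5cc(C)ccc5[nH]4)cc3)cc2)cc(OC)c1OC`, differs from compound 3 by one change: methoxy in place of hydrogen on an aromatic carbon, which is methoxy in place of hydrogen on an aromatic carbon.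

For the measured compounds named here, no measured step makes this exact change, so the evidence is indirect. The closest is a 1.0-fold lower number from compound 2 to compound 3 (0.01 log units; within the scatter), where 3,4-dimethoxyphenyl replaces 3-chlorophenyl. The other two steps are a 2.0-fold lower number from compound 1 to compound 2 (0.30 log units; within the scatter) and a 2.0-fold lower number from compound 1 to compound 3 (0.31 log units; beyond the scatter), and neither is large. With steps this small among these three compounds, no change beyond the scatter is expected in this assay, so no direction can be called. The expected result is a 1.1-fold lower number from compound 3 to compound 4 (0.04 log units; within the scatter). Compound 4 is estimated at 3200 nM, with an expected range of 1400 nM to 7000 nM.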

Compound 4, concentration for 50% growth inhibition: 170 nM
The estimate for compound 4 lay 19-fold (1.27 log units) above the measured number, outside the stated range (below it).
By their numbers in this assay, from the lowest: compound 4; then compounds 3, 2 and 1 (each within the scatter of the next, the first and the last beyond it).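

Placing one methoxy on this aromatic carbon, ortho to a methoxy group and meta to a large group, gives a 21-fold lower number from compound 3 to compound 4 (1.31 log units; beyond the scatter) in this assay and is a large step. Among the earlier compounds, exchanging the whole terminal aromatic group changed far less, with the largest step being a 2.0-fold lower number from compound 1 to compound 3 (0.31 log units; beyond the scatter) and so a much smaller one than this single added methoxy of 2 heavy atoms. No measurement shown gives a reason for the size of this step.

As far as these compounds go, whether methoxy itself is needed here remains open, since an ethoxy, a hydroxyl, a chlorine or a longer chain at this carbon could show whether other groups do the same. The compounds shown also leave open whether this methoxy would have a similar effect without the two methoxy groups already on the ring.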